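The source may hold more compounds than are shown below. What is called first, only, known or untested is meant among the compounds shown, and "the series" means these compounds.

In a functional assay on MCF7 cells (Homo sapiens) for antiproliferative activity, read by MTT assay, with a stated time of 24 h (on this read-out lower numbers stand for stronger inhibition and higher numbers for weaker inhibition), compound 1 `Cc1ccc(-c2nn(-c3ccccc3)cc2-c2nc3ccccc3n2S(=O)(=O)c2ccc(C)cc2)cc1` gives 570 nM and compound 2 `Cc1ccc(-c2nn(-c3ccccc3)cc2-c2nc3ccccc3n2S(=O)(=O)c2ccc(Br)cc2)cc1` gives 3160 nM as the higher of the two numbers. Within the data shown here, the only measured step, a 5.5-fold higher number from compound 1 to compound 2 (0.74 log units; beyond the scatter), came with bromo in place of methyl on an aromatic carbon. Compound 3 `Cc1ccc(-c2nn(-c3ccccc3)cc2-c2nc3ccccc3n2S(=O)(=O)c2ccc(C(F)(F)F)cc2)cc1` differs from compound 2 by trifluoromethyl in place of bromo on an aromatic carbon, para to a large group (trifluoromethyl in place of bromo on an aromatic carbon). Among the measured compounds shown here, no measured step covers this exchange, so the step from compound 1 offers only a rough guide to how far such a change can move the number. In this assay a small shift toward a lower number is expected, probably no larger than that measured step and perhaps none beyond the scatter. The estimated change is a 1.6-fold lower number from compound 2 to compound 3 (0.20 log units; within the scatter) on this reasoning. For compound 3 the expected value is 2000 nM, with an estimated range of 600 nM to 6000 nM for repeated measurements.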

Compound 3, half-maximal inhibitory concentration: 2340 nM
Compound 3: the middle estimate sits 1.2-fold (0.07 log units) below what was measured; the measured number falls inside the stated range.
By their numbers in this assay, from the lowest: compound 1; then compounds 3 and 2 (each within the scatter of the next).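

In this assay, the exchange of 4-bromophenyl to 4-(trifluoromethyl)phenyl, on an aromatic carbon para to a large group, does not tell the two groups apart: it gives a 1.4-fold lower number from compound 2 to compound 3 (0.13 log units; within the scatter). Trifluoromethyl in place of methyl at the same place gives a 4.1-fold higher number from compound 1 to compound 3 (0.61 log units; beyond the scatter), so a second group joins bromo in carrying the number beyond the scatter from compound 1, and the methyl compound stands apart from the other two. Nothing available explains why these groups fall as they do.

The compounds shown leave open whether the lower number of compound 1 is particular to methyl or would also come with hydrogen, ethyl or methoxy at this place. They also leave open how an amine or a carboxylic acid there would read.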